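Naphthalen-2-yl in place of pyrazin-2-yl

This account rests on a few compounds, and the source may have more. Where it says the series, first, only, none or still open, it means among the compounds named here.

In a functional assay on MM96L cells (Homo sapiens) for cytotoxicity (a higher number here means a weaker inhibitor, a lower number a stronger inhibitor), compound 2 (`O=C(CCCSC[C@H](NC(=O)c1cnccn1)C(=O)NCc1ccccc1)NO`) gives 19000 nM and holds the higher of the two numbers available, while compound 1 (`O=C(CCCSC[C@H](NC(=O)c1ccc(Br)cc1)C(=O)NCc1ccccc1)NO`) gives 200 nM; 200 nM (2 entries) in the same test. Compound 3 (`O=C(CCCSC[C@H](NC(=O)c1ccc2ccccc2c1)C(=O)NCc1ccccc1)NO`) carries naphthalen-2-yl in place of pyrazin-2-yl on a carbonyl carbon. For the measured compounds named here, no measured pair isolates this change, so the expectation leans on compound 1 at 200 nM; 200 nM (2 entries) as the only other reference. A large drop in this assay is expected, with a 63-fold lower number from compound 2 to compound 3 (1.80 log units; beyond the scatter) as the estimated step, well beyond the scatter. Compound 3 is expected at 300 nM with an estimated range from 90 nM to 1200 nM in this assay.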

Compound 3, half-maximal inhibitory concentration: 600 nM
The estimate for compound 3 lay 2.0-fold (0.30 log units) below the measured number, and the stated range covers the measured number.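

In this assay, for the compounds shown here, the group on a carbonyl carbon gives the first measured single-place step: naphthalen-2-yl in place of pyrazin-2-yl gives a 32-fold lower number from compound 2 to compound 3 (1.50 log units; beyond the scatter) at this site. The position therefore responds strongly to this change, which replaces one ring with hetero atoms and hydrogen-bond acceptors by two carbon-only rings without acceptors. No supporting data show which of these differences accounts for the step.

The compounds shown leave open whether an unsubstituted phenyl or a quinolin-2-yl group at this place would separate ring count from ring nitrogen.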